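A few compounds are considered here, and "the series" means these few. Any claim that something is new, unique, unknown or untested is made for them only; others in the source may bear on it.

Compound 2 `CCNc1nc(Nc2ccc(C#N)cc2)nc(Oc2ccc3ccccc3c2Cl)n1` was tested in an ADME assay on MT4 cells (Homo sapiens) for cytotoxicity, read by MTT assay, with a stated time of 4 days (on this read-out higher numbers stand for lower toxicity in this test and lower numbers for higher toxicity in this test), where compound 2 gives 188000 nM. For the measured compounds named here, this is the lowest of the two numbers measured so far, and the nearest is compound 1 `CNc1nc(Nc2ccc(C#N)cc2)nc(Oc2ccc3ccccc3c2)n1`, which in this assay gives 250000 nM; the gap between them lies within the usual scatter of repeated measurements, so the two cannot be told apart. Compound 3 `CNc1nc(Nc2ccc(C#N)cc2)nc(Oc2ccc3ccccc3c2Cl)n1` has not yet been measured. It differs from compound 2 in one place: hydrogen in place of methyl on a saturated chain carbon bound to a nitrogen on an aromatic ring. Going by the values given here, no pair of measured compounds differing only in this way exists here, so there is no measured step to lean on. With both measured numbers sitting close together, no shift beyond the scatter is expected in either direction, and the expected step is a 1.2-fold higher number from compound 2 to compound 3 (0.07 log units; within the scatter). Compound 3 is therefore estimated to give 220000 nM in this assay, with a likely range from 110000 nM to 450000 nM.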

Compound 3, half-maximal cytotoxic concentration: 171000 nM
Compound 3: the middle estimate sits 1.3-fold (0.11 log units) above what was measured; the range from low to high includes it.
By their numbers in this assay, from the lowest: compounds 3, 2 and 1 (each within the scatter of the next).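

In this assay, for the compounds shown here, going from ethylamino to methylamino gives a 1.1-fold lower number from compound 2 to compound 3 (0.04 log units; within the scatter) as the first single-place reading at this position, so hydrogen in place of methyl on a saturated chain carbon bound to a nitrogen on an aromatic ring leaves a difference that cannot be told from repeat-measurement noise. The result also allows a second single-place reading, chloro in place of hydrogen on an aromatic carbon, which gives a 1.5-fold lower number from compound 1 to compound 3 (0.16 log units; within the scatter) and is likewise too small to separate the two compounds. Nothing measured here offers a reason for either result.

As far as these compounds go, whether a longer chain such as propyl, or a cyclopropyl group, in place of the methyl of methylamino would shift the number beyond the scatter stays open. The same question stands for fluoro or methoxy in place of chloro on that aromatic carbon.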